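A few compounds are considered here, and "the series" means these few. Any claim that something is new, unique, unknown or untested is made for them only; others in the source may bear on it.

Compound 3 `CC(C)Nc1nnc(SCC(=O)N(Cc2cccc([N+](=O)[O-])c2)c2ccc(F)cc2)s1` gives 92.5% in an assay on isolated protein for inhibition of Amine oxidase [flavin-containing] A (Homo sapiens), read by fluorescence and Amplex Red, with a stated time of 30 min, tested at 1 mM (on this read-out higher numbers stand for a stronger effect at the one concentration tested and lower numbers for a weaker effect), the lowest of the three numbers shown, although compound 2 `COCCNc1nnc(SCC(=O)N(Cc2cccc([N+](=O)[O-])c2)c2ccc(F)cc2)s1` with 94.1% and compound 1 `CCCNc1nnc(SCC(=O)N(Cc2cccc([N+](=O)[O-])c2)c2ccc(F)cc2)s1` with 95% both lie within the scatter of it. Compound 4 `CCNc1nnc(SCC(=O)N(Cc2cccc([N+](=O)[O-])c2)c2ccc(F)cc2)s1` has not yet been measured; it differs from compound 3 by hydrogen in place of methyl on a saturated chain carbon bound to a nitrogen on an aromatic ring and a saturated chain carbon. The measured steps that bear on this place are a number 2.5 percentage points lower from compound 1 to compound 3 (within the scatter) and a number 1.6 percentage points lower from compound 2 to compound 3 (within the scatter), alongside a number 0.9 percentage points lower from compound 1 to compound 2 (within the scatter); every change so far at the nitrogen on the aromatic ring left the number within the scatter. The step to compound 4 is therefore expected to be no change at the digits printed from compound 3 to compound 4 (within the scatter), with nothing beyond the scatter. Compound 4 is estimated at 92.5%, between 85% and 97%.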

Compound 4, a percentage reported as inhibition, at one concentration (the size of the read-out at that concentration, not a potency): 93.6%
Compound 4: the middle estimate sits 1.1 percentage points below what was measured; the range from low to high includes it.
By their numbers in this assay, from the lowest: compounds 3, 4, 2 and 1 (each within the scatter of the next).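

In this assay, isopropylamino to ethylamino gives a number 1.1 percentage points higher from compound 3 to compound 4 (within the scatter) and the other two steps read a number 0.5 percentage points lower from compound 2 to compound 4 (within the scatter) and a number 1.4 percentage points lower from compound 1 to compound 4 (within the scatter) as the methoxy or methyl goes. The ethyl group therefore stays within the scatter of the branched, ether-bearing and propyl groups on this nitrogen at the one concentration tested. Nothing available explains this result.

Going by these compounds, whether a longer chain, or a chain ending in an amine or a carboxylic acid, would leave the number within the scatter stays open. On these data alone, whether these four compounds differ in the size of their effect at other concentrations also stays open, as a single-concentration percentage does not give it.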